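The source may report more compounds than this note shows. Statements on the series, on what has been measured and on what is new or still open speak of the compounds shown alone.

The compounds described here share one core, and they differ only in the groups attached to it. Within the data shown here, compound 1 `C=CCN(C)c1nc(N)nc2c1ncn2[C@H]1C[C@H](N=[N+]=[N-])[C@@H](CO)O1` is the single compound for which an ADME assay on CCRF-CEM cells (Homo sapiens) for cytotoxicity, with a stated time of 5 days (a higher number here means a weaker inhibitor, a lower number a stronger inhibitor), gives a number: in this assay compound 1 gives 27000 nM. Compound 2 `CNc1nc(Cl)nc2c1ncn2[C@H]1C[C@H](N=[N+]=[N-])[C@@H](CO)O1` reaches in this assay only a limit, > 100000 nM, which is a boundary of the assay and not a number. Compound 3 `COc1nc(NC2CC2)c2ncn([C@H]3C[C@H](N=[N+]=[N-])[C@@H](CO)O3)c2n1` likewise gives in this assay only a limit, > 100000 nM. Among the measured compounds shown here, compound 1 therefore stands as the only measured value, and the limit of > 100000 nM in this assay, at which 2 of the 3 values shown sit, describes where the two others sit.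

Compound 4 `CC(C)(CO)Nc1nc(N)nc2c1ncn2[C@H]1C[C@H](N=[N+]=[N-])[C@@H](CO)O1` has not yet been tested in this assay. It differs from compound 1 in a single place: (1-(hydroxymethyl)-1-methylethyl)amino in place of allyl(methyl)amino on an aromatic carbon. For the measured compounds named here, no step between two measured compounds is available, so the size of the change can only be an expectation. The expected step from compound 1 to compound 4, a 1.9-fold higher number from compound 1 to compound 4 (0.27 log units; within the scatter), is estimated to go toward a higher number, that is toward a weaker inhibitor, by roughly the usual scatter or a little more. Compound 4 is expected to give about 50000 nM in this assay, within a range from 15000 nM to 150000 nM, and it may well end at a limit like compound 2 and compound 3.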

Compound 4, half-maximal inhibitory concentration: > 100000 nM
Compound 4: only a limit was reported (the forecaster's own chance of this, stated with the estimate: 40%); at least 2.0-fold (0.30 log units) between middle value and limit.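

Placing (1-(hydroxymethyl)-1-methylethyl)amino instead of allyl(methyl)amino on this aromatic carbon gives an at least 3.7-fold higher number from compound 1 to compound 4 (0.56 log units; beyond the scatter), the first step in this set that can be read, and it shows that in this assay the group at this one position matters, with the change going toward a weaker inhibitor. On these data alone, the result for compound 4 is a limit of the assay and not a number, so the step gives only a smallest size and its full size stays unknown. The entering group carries hydrogen-bond donors where the leaving group has none, and allyl(methyl)amino in compound 1 remains the only group here tied to a measured number, which sets compound 1 apart from the rest of the set: the limit of > 100000 nM in this assay, at which 3 of the 4 values shown sit.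

As far as these compounds go, it remains open whether a propyl(methyl)amino or a dimethylamino group at this position would give a number such as that of compound 1 or a limit such as that of compound 4. A tert-butylamino group, which lacks the hydroxyl of the entering group, would help to separate the part played by that hydroxyl from the part played by the branched carbon.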